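A few compounds are considered here, and "the series" means these few. Any claim that something is new, unique, unknown or untested is made for them only; others in the source may bear on it.

The study compares two measured compounds that share a core and differ in both the aryl group and the heteroaryl thioether. Compound 1 `Cc1ccc(-c2cs/c(=N/NC(=O)CSc3nncn3C)n2-c2ccccc2)cc1` carries a methyl-bearing phenyl ring and a triazole-linked side chain. In a functional assay on C6 cells (Rattus norvegicus) for cytotoxicity, read by MTT assay, with a stated time of 24 h (on this read-out lower numbers stand for stronger inhibition and higher numbers for weaker inhibition), compound 1 gives 56 ug/mL. Compound 2 `O=C(CSc1ncccn1)N/N=c1/scc(-c2ccc(Br)cc2)n1-c1ccccc1` carries a bromine-bearing phenyl ring and a pyrimidine-linked side chain. In this assay compound 2 yields only a limit of the assay, not a number: > 200 ug/mL. On these data alone, compound 2 thus stands at the limit of > 200 ug/mL in this assay, at which 1 of the 2 values shown sits, and where it truly lies beyond that bound is unknown. Within the data shown here, compound 1 and compound 2 differ in two places, so no single step between them can be read off.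

Compound 3 `Cc1ccc(-c2cs/c(=N/NC(=O)CSc3ncccn3)n2-c2ccccc2)cc1` is the next compound to be measured. It differs from compound 2 by methyl in place of bromo on an aromatic carbon, taking 4-bromophenyl to 4-methylphenyl, while the pyrimidine side chain is kept. Among the measured compounds shown here, no step of this kind is known here, so its direction in this assay can only be guessed. Compound 3 is expected to land near 150 ug/mL, within 60 ug/mL to 300 ug/mL. For compound 3 this means an expected step of an at least 1.3-fold lower number from compound 2 to compound 3 (0.12 log units; that floor lies within the scatter), a moderate gain at most, with a real chance that only a limit is reported again.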

Compound 3, half-maximal inhibitory concentration: 85 ug/mL
Compound 3: the middle estimate sits 1.8-fold (0.25 log units) above what was measured, and the stated range covers the measured number.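

With the pyrimidine side chain kept, methyl in place of bromo on an aromatic carbon gives, in this assay, an at least 2.3-fold lower number from compound 2 to compound 3 (0.37 log units; beyond the scatter), a step beyond the usual scatter. This shows that the group at this place, para to a large group, does bear on the read-out, which the earlier pair, differing in two places, could not show, although the step starts from a limit of the assay for compound 2 and not from a number: the limit of > 200 ug/mL in this assay, at which 1 of the 3 values shown sits.

With the 4-methylphenyl group kept, pyrimidin-2-yl in place of 4-methyl-4H-1,2,4-triazol-3-yl on a sulfur gives a 1.5-fold higher number from compound 1 to compound 3 (0.18 log units; within the scatter), so in this assay this change of side chain cannot be told apart from the scatter.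

The compounds shown leave open how far the true number for compound 2 lies beyond its limit, and so how large the step from bromo to methyl really is. They also leave open whether that step holds with the 4-methyl-4H-1,2,4-triazol-3-yl side chain, and how an amine or a carboxylic acid on the same aromatic carbon would compare with methyl.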